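Removing the anilide chloro from a salicylamide dipeptide

This account rests on a few compounds, and the source may have more. Where it says the series, first, only, none or still open, it means among the compounds named here.

Compound 2 `CC(C)[C@H](NC(=O)c1cc(Cl)ccc1O)C(=O)Nc1cccc(Cl)c1` is one of two measured members of this small series. In a functional assay on K562 cells (Homo sapiens) for cytotoxicity, with a stated time of 72 h (on this read-out higher numbers stand for weaker inhibition and lower numbers for stronger inhibition), compound 2 gives > 10000 nM, which is a limit of the assay rather than a number. Compound 1 `C[C@H](NC(=O)c1cc(Cl)ccc1O)C(=O)Nc1cccc(Cl)c1` differs from compound 2 only by methyl in place of isopropyl on the saturated chain carbon. In this assay compound 1 gives > 10000 nM, again a limit. The step that the two limits leave unreadable from compound 1 to compound 2 is thus not readable, and both values sit at the limit of > 10000 nM in this assay, at which 2 of the 2 values shown sit. Compound 3 `CC(C)[C@H](NC(=O)c1cc(Cl)ccc1O)C(=O)Nc1ccccc1` carries the change (hydrogen in place of chloro on an aromatic carbon), on an aromatic carbon of a six-membered aromatic ring of carbon only, meta to a large group. No measured step touches that ring, so the change has no precedent among these compounds. The step that the limit leaves unreadable from compound 2 to compound 3 is expected to leave compound 3 at or past the same limit. Compound 3 is estimated at 15000 nM, within 5000 nM to 50000 nM.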

Compound 3, half-maximal inhibitory concentration: > 10000 nM
Compound 3 was reported as a limit; the forecaster's own chance of this, stated with the estimate: 85%; the middle value does not contradict the limit.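

Compound 2 and compound 3 both stand at a limit of the read-out in this assay, so no step between them can be read: the limit of > 10000 nM in this assay, at which 3 of the 3 values shown sit.

The compounds shown leave open what the actual values of all three are, and whether 3-chlorophenyl and phenyl differ at all here.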